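The compounds below may be only part of what the source reports. "The series", "measured", "known", "first", "only" and "open" are said of these compounds alone.

Measured compounds:
- compound 1 `O=C(NCCOC(=S)Nc1ccc([N+](=O)[O-])cc1Cl)c1cccnc1`: > 800000 nM
- compound 2 `Cc1ccc(NC(=S)OCCNC(=O)C(C)(C)Oc2ccc(Cl)cc2)cc1`: 771000 nM
- compound 3 `Cc1ccc(NC(=S)OCCNC(=O)c2cccnc2)cc1`: 726000 nM

In an ADME assay on H9c2 cells (Rattus norvegicus) for cytotoxicity, read by MTT assay, with a stated time of 48 h (a lower number here means a stronger inhibitor, a higher number a weaker inhibitor), compound 1 reaches only a limit, namely > 800000 nM. Compound 3 gives 726000 nM, the lowest of the two numbers shown, and compound 2 gives 771000 nM, a value within the scatter of that of compound 3. Compound 4 `O=C(NCCOC(=S)Nc1ccccc1)c1cccnc1` is not yet measured. It differs from compound 3 by one change: hydrogen in place of methyl on an aromatic carbon. Going by the values given here, no step between measured compounds is available; with all values gathered near (the limit of > 800000 nM in this assay, at which 1 of the 3 values shown sits), the step from compound 3 to compound 4 is expected to stay within the scatter. Compound 4 is therefore estimated at 750000 nM, with a range from 380000 nM to 1500000 nM, implying a 1.0-fold higher number from compound 3 to compound 4 (0.01 log units; within the scatter).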

Compound 4, half-maximal inhibitory concentration: > 800000 nM
Compound 4: no number, only a limit (the forecaster's own chance of this, stated with the estimate: 35%); middle value at least 1.0-fold (0.02 log units) away from the limit.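

In this assay, going by these compounds alone, the change from 4-methylphenyl to phenyl, para to a large group, gives the first comparison at this position: an at least 1.1-fold higher number from compound 3 to compound 4 (0.04 log units; that floor lies within the scatter). The value of compound 4 is a limit, so this step has a floor but no measured size. Because the values gather at the top of the range, the effect of the methyl stays unresolved: the limit of > 800000 nM in this assay, at which 2 of the 4 values shown sit. The compounds shown leave open whether an amine, a carboxylic acid or a longer chain at this position would give a clearly lower number.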